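Aryl-piperazine succinimide amides: fluoro to trifluoromethyl step

The compounds below may be only part of what the source reports. "The series", "measured", "known", "first", "only" and "open" are said of these compounds alone.

Measured in a functional assay on the whole organism (strain Swiss) with Mus musculus as the target, in the maximal electroshock model, with a stated time of 0.25 h, at a dose of 100 mg/kg by the intraperitoneal route; on this read-out lower numbers stand for a weaker effect and higher numbers for a stronger effect at the one dose given:
compound 1 `CCC(C(=O)N1CCN(c2cccc(F)c2)CC1)N1C(=O)CCC1=O` gives 0%
compound 2 `CC(C(=O)N1CCN(c2ccccc2F)CC1)N1C(=O)CCC1=O` gives 75%
compound 3 `CC(C(=O)N1CCN(c2ccccc2C(F)(F)F)CC1)N1C(=O)CCC1=O` gives 100%

Compound 1 stands lowest of the three; its values against compound 2 and compound 3 both lie beyond the scatter. The difference between the core of compound 1 and the core of compound 2 is not broken down here. Between compound 2 and compound 3 the change is trifluoromethyl in place of fluoro on an aromatic carbon, and in this assay it gave a number 25 percentage points higher from compound 2 to compound 3 (beyond the scatter).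

Compound 4 `CCC(C(=O)N1CCN(c2cccc(C(F)(F)F)c2)CC1)N1C(=O)CCC1=O` is not yet measured. It differs from compound 1 by trifluoromethyl in place of fluoro on an aromatic carbon. This is the same kind of change as from compound 2 to compound 3, not the same: there the place is ortho to a large group, here it is meta to a large group, and the two starting cores are not the same.

For compound 4 a rise from the floor set by compound 1 is expected, since the only measured case of this kind of change, a number 25 percentage points higher from compound 2 to compound 3 (beyond the scatter), went upward. Set beside that step, the step expected here is a number 25 percentage points higher from compound 1 to compound 4 (beyond the scatter). It rests on one pair only, on a different place and a different core, so it is held loosely. Compound 4 is estimated at 25%, between 0% and 75%.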

Compound 4, a percentage reported as activity, at one dose (the size of the read-out at that dose, not a potency): 75%
Compound 4: the middle estimate sits 50 percentage points below what was measured; the measured number falls inside the stated range.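

In this assay, trifluoromethyl in place of fluoro on an aromatic carbon again moved the read-out upward, with a number 75 percentage points higher from compound 1 to compound 4 (beyond the scatter), so the direction of the change is the same on both cores shown. The size of the step did not carry over from one core to the other: the same change on two cores in this assay, a number 25 percentage points higher (beyond the scatter) from compound 2 to compound 3 and a number 75 percentage points higher (beyond the scatter) from compound 1 to compound 4, 50 percentage points apart, beyond the scatter of two such steps

This does not show which difference sets the size of the step, as the two pairs differ both in the core and in where the group sits on the aromatic ring, and compound 3, at 100%, stands at the top of a percentage read-out, so the step ending there had little room to be larger. Among these compounds, with only two pairs and one dose, the direction is an observation on these compounds and not a rule for the series, and the size of the step on a further core cannot be predicted from them.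

The compounds shown leave open how a chlorine, a methoxy group or a nitrile would compare with fluoro and trifluoromethyl on the aromatic ring. They also leave open what a longer chain would do in place of the short chains carried by these cores.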